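Methoxy added to the aryl of compound 3

The source may hold more compounds than are shown below. What is called first, only, known or untested is meant among the compounds shown, and "the series" means these compounds.

Working notes on the series. Compound 1 `Cc1ccc(/C=C/C2=C(/C=N/O)CCC2)cc1` and compound 2 `O/N=C/C1=C(/C=C/c2ccc(F)cc2)CCC1` carry a styryl arm on the shared core; in an assay on HEK293T cells for inhibition of fibroblast growth factor 23 (Homo sapiens), read by a luciferase reporter, with a stated time of 5 h (on this read-out lower numbers stand for stronger inhibition and higher numbers for weaker inhibition), compound 1 gives 200 nM and compound 2 gives 370 nM. Within the data shown here, the one measured step, a 1.9-fold higher number from compound 1 to compound 2 (0.27 log units; within the scatter), is small. Compound 3 `O/N=C/C1=C(c2ccccc2)CCC1` lacks the two-carbon linker and has the aryl directly on the core; in this assay compound 3 gives 10000 nM, the highest number of the three, and its gaps to compound 2 and to compound 1 are both beyond the scatter.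

Compound 4 `COc1ccc(C2=C(/C=N/O)CCC2)cc1` is the next member; it differs from compound 3 by methoxy in place of hydrogen on an aromatic carbon. Among the measured compounds shown here, no measured step covers a substituent on a directly attached aryl; the only step available, a 1.9-fold higher number from compound 1 to compound 2 (0.27 log units; within the scatter), concerns a substituent on a styryl aryl and is within the scatter. With so little to go on, compound 4 is expected to sit near compound 3, its step in this assay estimated as a 1.3-fold lower number from compound 3 to compound 4 (0.10 log units; within the scatter). The estimate for compound 4 in this assay is 8000 nM, with a range from 3000 nM to 20000 nM.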

Compound 4, half-maximal inhibitory concentration: 12300 nM
Compound 4: middle estimate off by 1.5-fold (0.19 log units), on the low side; low and high end bracket the measured number.
By their numbers in this assay, from the lowest: compounds 1 and 2 (each within the scatter of the next); then compounds 3 and 4 (each within the scatter of the next).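

In this assay methoxy in place of hydrogen on an aromatic carbon, para to a group of 8 heavy atoms, gives a step of a 1.2-fold higher number from compound 3 to compound 4 (0.09 log units; within the scatter) and does not separate compound 4 from compound 3. Among these compounds, the earlier compounds offered a substituent step only on a styryl aryl; this is the first step on an aryl attached directly to the core, and it too lies within the scatter. Nothing available here bears on the reason for this result.

Still open, from the compounds shown here alone, is whether an amine or a carboxylic acid at this place on the aryl of compound 3 would move the number beyond the scatter. Also open, going by these compounds, is whether methoxy on the styryl aryl of compound 1 would give a step of similar size.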